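This account rests on a few compounds, and the source may have more. Where it says the series, first, only, none or still open, it means among the compounds named here.

Measured so far:
compound 1, `CC(C)=C1C(=O)Nc2ccc(OCCc3ccccc3)cc21` — "not active" (no number reported)
compound 2, `Cn1c(=O)[nH]c2ccc(OCCOc3ccc(Cl)cc3)cc21` — 9.94%
compound 3, `Cn1c(=O)[nH]c2ccc(OCc3cccc(F)c3)cc21` — 5.36%

Three compounds of the series have been run in an assay on cells for inhibition of Amine oxidase [flavin-containing] B (Homo sapiens), read by fluorescence, with stated times of 30 min and 15 min, tested at 1 uM; a lower number here means less inhibition, a higher number more inhibition at the concentration tested (going by the name of the read-out). Compound 1 `CC(C)=C1C(=O)Nc2ccc(OCCc3ccccc3)cc21` carries a different core and returned no number, only the report "not active" (no number reported). Compound 2 `Cn1c(=O)[nH]c2ccc(OCCOc3ccc(Cl)cc3)cc21` and compound 3 `Cn1c(=O)[nH]c2ccc(OCc3cccc(F)c3)cc21` share the same core and differ only in the group attached through the ether oxygen. In this assay compound 2 gives 9.94% and compound 3 gives 5.36%; the gap between these two numbers lies within the usual scatter of the measurement, so compound 3 and compound 2 are not distinguished, and both sit at a low level of inhibition at the concentration tested. Among the measured compounds shown here, no step between measured compounds that differ in a single place is available.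

Compound 4 `Cn1c(=O)[nH]c2ccc(OCc3cccc(Cl)c3)cc21` has not yet been measured. Against compound 3 the change is chloro in place of fluoro on an aromatic carbon. For the measured compounds named here, with no single-point step to draw on, the expectation rests on the two low numbers already seen. The step from compound 3 to compound 4 is expected to be no larger than the scatter: a number 1.6 percentage points higher from compound 3 to compound 4 (within the scatter). Compound 4 is therefore estimated at 7%, within -5% to 20%.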

Compound 4, a percentage reported as inhibition, at one concentration (the size of the read-out at that concentration, not a potency): 8.89%
Beside the measured number, compound 4's estimate is 1.9 percentage points below it; the range from low to high includes it.
By their numbers in this assay, from the lowest: compounds 3, 4 and 2 (each within the scatter of the next).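

The pair gives the series its first step at a single place: in this assay, chloro in place of fluoro on an aromatic carbon, meta to a large group, gives a number 3.5 percentage points higher from compound 3 to compound 4 (within the scatter), so this exchange of one halogen for the other does not separate the two compounds at the concentration tested. Both compounds remain at a low level of inhibition, and this halogen exchange therefore offers no sign of a route to a higher reading in this assay. No measurement at hand accounts for the step or for its small size.

It remains open whether any group on this aromatic carbon can move the reading beyond the scatter, since the compounds shown place only fluoro and chloro there, and a methoxy, a nitrile, a trifluoromethyl or an amine would put that question to a wider test. From the compounds shown here alone, it is equally open whether a longer chain on the ether oxygen, or an ethyl group in place of the methyl on the shared core, would change the reading when all else stays the same.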